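Heteroaryl swap on the shared core: furan to pyrazole

The compounds below may be only part of what the source reports. "The series", "measured", "known", "first", "only" and "open" are said of these compounds alone.

Measured compounds:
compound 1, `Cc1cccnc1-c1ccccc1OCC1=NCCN1`, in a functional assay for activation of Alpha-1D adrenergic receptor (Homo sapiens), read by calcium flux (on this read-out lower numbers stand for an effect already at smaller amounts and higher numbers for an effect only at larger amounts of compound), compound 1 gives < 100000 nM, a limit of the assay
compound 2, `Cc1ccnc(-c2ccccc2OCC2=NCCN2)c1`, in this assay compound 2 gives < 100000 nM, a limit of the assay
compound 3, `c1coc(-c2ccccc2OCC2=NCCN2)c1`, in this assay compound 3 gives < 100000 nM, a limit of the assay

Compound 3 sits at the limit of < 100000 nM in this assay, at which 3 of the 3 values shown sit. Among the compounds with values here, no number was obtained for compound 3, only that limit, and the same holds for the other two members, so no ranking among them is possible and no step between measured compounds can be computed.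

Compound 4, `c1ccc(-c2cc[nH]n2)c(OCC2=NCCN2)c1`, is the next member to be measured in this assay. Its difference from compound 3 is 1H-pyrazol-3-yl in place of furan-2-yl on an aromatic carbon. The incoming group brings one hydrogen-bond donor where the outgoing one brought none.

With every measured value a limit, there is no basis for a direction or a size of step. The expected step from compound 3 to compound 4 is therefore a step that the limit leaves unreadable from compound 3 to compound 4, understood as no change beyond the scatter, with a real chance that compound 4 again returns only a limit. Compound 4 is estimated at 30000 nM, within 3000 nM to 100000 nM.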

Compound 4, half-maximal effective concentration: < 100000 nM
Compound 4: a limit, no number; the forecaster's own chance of this, stated with the estimate: 55%; the middle value lies beyond the limit too.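

No new step can be read: compound 3 and compound 4 both return only a limit, so the change from furan-2-yl to 1H-pyrazol-3-yl has no readable size, and the series stays where it was: the limit of < 100000 nM in this assay, at which 4 of the 4 values shown sit.

The compounds shown leave open how any of these members ranks in this assay, since none has yielded an actual number.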